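The source may report more compounds than this note shows. Statements on the series, on what has been measured and on what is new or still open speak of the compounds shown alone.

In an ADME assay on TZM cells (Homo sapiens) for cytotoxicity, read by CellTiter-Glo, with a stated time of 48 h (on this read-out lower numbers stand for higher toxicity in this test and higher numbers for lower toxicity in this test), compound 1 `COc1ccc(C2=Cc3ccc(F)cc3C(CC(=O)CO)N2c2ccc(C#N)cc2)cc1` gives 39700 nM and compound 2 `COc1ccc(C2=Cc3ccc(F)cc3C(CC(=O)CO)N2c2ccc([N+](=O)[O-])cc2)cc1` gives 46400 nM. For the measured compounds named here, compound 1 thus holds the lower of only two numbers, but the gap does not separate them: the measured step is a 1.2-fold higher number from compound 1 to compound 2 (0.07 log units; within the scatter), for nitro in place of cyano on an aromatic carbon. Compound 3 `COc1ccc(C2=Cc3ccc(F)cc3C(CC(=O)C(C)O)N2c2ccc(C#N)cc2)cc1` differs from compound 1 elsewhere: methyl in place of hydrogen on a saturated chain carbon bound to a carbonyl carbon and an oxygen on a saturated carbon, that is, hydroxymethyl to 1-hydroxyethyl. Going by the values given here, no measured step covers this change. Among the compounds with values here, the one available step, a 1.2-fold higher number from compound 1 to compound 2 (0.07 log units; within the scatter), bears on it only indirectly, as a sign that one change to this scaffold left the number within the scatter. No step beyond the scatter is therefore expected in this assay, and no direction can be favoured. The expected step is a 1.0-fold higher number from compound 1 to compound 3 (0.00 log units; within the scatter). Compound 3 is estimated at 40000 nM, with an expected range of 20000 nM to 75000 nM.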

Compound 3, half-maximal cytotoxic concentration: 24100 nM
Compound 3: the middle estimate sits 1.7-fold (0.22 log units) above what was measured, and the stated range covers the measured number.
By their numbers in this assay, from the lowest: compounds 3, 1 and 2 (each within the scatter of the next).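

The earlier compounds shown here tested only a change on an aromatic carbon, whereas compound 3 carries its change on a saturated chain carbon bound to a carbonyl carbon and an oxygen on a saturated carbon. In this assay, hydroxymethyl to 1-hydroxyethyl gives a 1.6-fold lower number from compound 1 to compound 3 (0.22 log units; within the scatter), so this added methyl, like the nitro for cyano exchange, leaves the number within the scatter. No available measurement accounts for the size of this step.

The compounds shown leave open whether a longer chain, such as 1-hydroxypropyl, or an amine in place of the hydroxyl at this position would also stay within the scatter. They also leave open how 1-hydroxyethyl would read alongside nitro on the aromatic carbon.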